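This account rests on a few compounds, and the source may have more. Where it says the series, first, only, none or still open, it means among the compounds named here.

Compound 1: `O=S(=O)(c1cccc(F)c1)c1ccc2c(c1)CCC[C@H]2CN1CC(O)C1` — 0.1 nM in an assay on isolated protein for displacement of a labelled ligand from 5-hydroxytryptamine receptor 6 (Homo sapiens); a lower number here means a stronger inhibitor, a higher number a weaker inhibitor
Compound 2: `O=S(=O)(O)CCCNC[C@@H]1CCCc2cc(S(=O)(=O)c3cccc(F)c3)ccc21` — 1.26 nM in this assay

Of the compounds shown here, two sharing the same core have been measured. Compound 1 gives 0.1 nM in this assay, and compound 2 gives 1.26 nM in this assay, which is the higher of the two numbers. Going by the values given here, the single measured step, a 13-fold higher number from compound 1 to compound 2 (1.10 log units; beyond the scatter), is a large one and lies beyond the scatter.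

Compound 3, `CNC(=O)NC[C@@H]1CCCc2cc(S(=O)(=O)c3cccc(F)c3)ccc21`, has not yet been measured. It differs from compound 2 in one place: methylcarbamoyl in place of 3-sulfopropyl on an amine nitrogen. Among the compounds with values here, only the step from compound 1 to compound 2 bears on this, and only loosely, since it changed a different part of the same side chain; it showed that altering what hangs from that chain carbon can shift the number by a large amount in this assay. With no measured urea among the compounds, the direction is uncertain, but a further move away from the two measured side chains is more likely to raise the number than lower it. Compound 3 is therefore expected to give about 15 nM in this assay, within a range of 2 nM to 100 nM, an expected step of a 12-fold higher number from compound 2 to compound 3 (1.08 log units; beyond the scatter).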

Compound 3, inhibition constant: 0.398 nM
Compound 3: the middle estimate sits 38-fold (1.58 log units) above what was measured, and the stated range ends above it.
By their numbers in this assay, from the lowest: compound 1; then compound 3; then compound 2.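

In this assay, replacing 3-sulfopropyl with methylcarbamoyl on the amine nitrogen gives a 3.2-fold lower number from compound 2 to compound 3 (0.50 log units; beyond the scatter), so a change at this place on the side chain can lower the number as well as raise it, and a group with fewer heavy atoms is accepted here. The other comparison, with (methylcarbamoyl)amino in place of 3-hydroxyazetidin-1-yl, gives a 4.0-fold higher number from compound 1 to compound 3 (0.60 log units; beyond the scatter), which means the new group recovers part of the rise seen with 3-sulfopropyl but does not reach the level of the azetidine, and compound 1 remains the lowest of the three. Nothing available explains why the numbers move in this way.

As far as these compounds go, the step from 3-sulfopropyl to methylcarbamoyl alters the size of the group and its atoms together, so it remains open which of these matters, or whether both do. A carboxylic acid on the same propyl chain would keep the chain and alter only its end, while ethylcarbamoyl would keep the carbonyl and lengthen the group by one carbon, so each would test one of these alone.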